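Removing the methoxy from the benzylamide of compound 2

The source may hold more compounds than are shown below. What is called first, only, known or untested is meant among the compounds shown, and "the series" means these compounds.

Measured so far in a functional assay on HCT-116 cells (Homo sapiens) for cytotoxicity, read by MTT assay, with a stated time of 72 h; on this read-out higher numbers stand for weaker inhibition and lower numbers for stronger inhibition:
compound 1, `C[C@@H](Nc1c(C(=O)NCc2ccc(F)cc2)nc(Br)c2cccnc12)c1ccccc1`: > 20000 nM.
compound 2, `COc1cccc(CNC(=O)c2nc(Br)c3cccnc3c2N[C@H]2CC[C@H](N)CC2)c1`: 6000 nM.
compound 3, `N[C@H]1CC[C@H](Nc2c(C(=O)NCc3ccc(F)cc3)nc(N3CCCCC3)c3cccnc23)CC1`: 8000 nM.

For compound 1 the value is a limit of this assay, not a number (the limit of > 20000 nM in this assay, at which 1 of the 3 values shown sits). Compound 2 and compound 3 give numbers within the scatter of each other, so no order between them is read. Compound 4, `N[C@H]1CC[C@H](Nc2c(C(=O)NCc3ccccc3)nc(Br)c3cccnc23)CC1`, remains to be measured in this assay. It differs from compound 2 by hydrogen in place of methoxy on an aromatic carbon, that is, 3-methoxybenzyl to benzyl on the amide side. For the measured compounds named here, no measured pair shows this change, so its size is unknown. The step from compound 2 to compound 4 is expected to be small, a 1.2-fold higher number from compound 2 to compound 4 (0.07 log units; within the scatter), none beyond the scatter. Compound 4 is estimated at 7000 nM in this assay, with a range from 2500 nM to 20000 nM.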

Compound 4, half-maximal inhibitory concentration: 7000 nM
Compound 4: middle estimate and measured number agree at the digits printed; measured number inside the range.
By their numbers in this assay, from the lowest: compounds 2, 4 and 3 (each within the scatter of the next). At a limit, above all of these: compound 1.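

In this assay, the first pair differing at this position gives a 1.2-fold higher number from compound 2 to compound 4 (0.07 log units; within the scatter), so hydrogen in place of methoxy on an aromatic carbon, meta to a large group, leaves the number within the scatter. For the compounds shown here, the earlier compounds offered no such pair, so this is the first reading of the change, and it separates 3-methoxybenzyl from benzyl on the amide side by no order. Nothing shown gives a cause for this step. Open, going by these compounds, is whether an amine or a carboxylic acid in place of the methoxy, or a longer chain in place of the benzyl, would move the number beyond the scatter.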